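The source may report more compounds than this note shows. Statements on the series, on what has been measured and on what is new or still open speak of the compounds shown alone.

Measured in a functional assay on HepG2 cells (Homo sapiens) for cytotoxicity, read by MTT assay, with a stated time of 48 h; on this read-out higher numbers stand for weaker inhibition and lower numbers for stronger inhibition:

compound 1, `COc1cc(/C=C/C(=O)/C=C/c2nc3cc(Cl)ccc3n2C)ccc1O`: 4000 nM
compound 2, `COc1cc(/C=C/C(=O)/C=C/c2nc3cc([N+](=O)[O-])ccc3n2C)ccc1O`: 3700 nM
compound 3, `COc1ccc(/C=C/C(=O)/C=C/c2nc3cc(Cl)ccc3n2C)cc1O`: 4100 nM

For the measured compounds named here, the three compounds measured so far sit close together. Compound 1 and compound 2 share one core and differ only by nitro in place of chloro on an aromatic carbon; that change made the step of a 1.1-fold lower number from compound 1 to compound 2 (0.03 log units; within the scatter). Compound 3 is built on a second core that has the same atoms as the core of compound 1, joined differently; the difference between the two cores is not broken down here. On this assay compound 3 stands nearest to compound 1 and furthest from compound 2, and both of those gaps lie within the scatter, so no order among the three can be read from the numbers.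

Compound 4, `COc1ccc(/C=C/C(=O)/C=C/c2nc3cc([N+](=O)[O-])ccc3n2C)cc1O`, has not yet been measured. Going by the values given here, it differs from compound 3 by nitro in place of chloro on an aromatic carbon, the same change as the one from compound 1 to compound 2, made at the same place. Because the earlier pair gave a 1.1-fold lower number from compound 1 to compound 2 (0.03 log units; within the scatter), the step from compound 3 to compound 4 is expected to be of similar size, a 1.1-fold lower number from compound 3 to compound 4 (0.03 log units; within the scatter), which rests on that single precedent and on the closeness of all three measured values. Compound 4 is therefore estimated at 3800 nM, most likely between 2000 nM and 7500 nM.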

Compound 4, half-maximal inhibitory concentration: 4600 nM
The estimate for compound 4 lay 1.2-fold (0.08 log units) below the measured number, within the range that was stated.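

In this assay, nitro in place of chloro on an aromatic carbon gave a 1.1-fold higher number from compound 3 to compound 4 (0.05 log units; within the scatter), and 3-hydroxy-4-methoxyphenyl in place of 4-hydroxy-3-methoxyphenyl gave a 1.2-fold higher number from compound 2 to compound 4 (0.09 log units; within the scatter) on the nitro-bearing compounds. Set beside the earlier step, the nitro for chloro change carried from one core to the other with no difference that these numbers can separate: the same change on two cores in this assay, a 1.1-fold lower number (0.03 log units; within the scatter) from compound 1 to compound 2 and a 1.1-fold higher number (0.05 log units; within the scatter) from compound 3 to compound 4, 1.2-fold (0.08 log units) apart, within the scatter of two such steps. For the compounds shown here, this shows only that the change left the number within the scatter on both cores; it gives the change no direction, and with just two pairs it does not show that the same would hold on any further core or in a series whose numbers spread more widely.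

The compounds shown carry only chloro or nitro on this aromatic carbon, so it remains open whether an amine, a carboxylic acid or a longer chain there would also leave the number within the scatter. Going by these compounds, all four compounds are also read only in this assay, so it remains open whether the closeness of their numbers would persist in a different cell type or read-out.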